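The source may hold more compounds than are shown below. What is called first, only, known or untested is meant among the compounds shown, and "the series" means these compounds.

Compound 1 `CC(C)[C@H](c1ccc(C(=O)NCc2nn[nH]n2)cc1)N1C(=O)C(c2cc(Cl)cc(Cl)c2)=N[C@]12CC[C@@H](C(C)(C)C)CC2` carries an isopropyl group on the chain carbon that links the ring nitrogen and the aromatic ring. Among the measured compounds shown here, in a functional assay on CHO cells for antagonist activity at Glucagon receptor (Homo sapiens), read by cAMP accumulation, with stated times of 30 min and 45 min (on this read-out lower numbers stand for stronger inhibition and higher numbers for weaker inhibition), compound 1 gives 2200 nM, the highest of the two numbers measured so far. Compound 2 `CC(C)(C)CC[C@H](c1ccc(C(=O)NCc2nn[nH]n2)cc1)N1C(=O)C(c2ccc(F)cc2)=N[C@]12CC[C@@H](C(C)(C)C)CC2` differs from compound 1 in two places, with a longer branched chain on that carbon and a different halogen pattern on the aryl ring; in this assay compound 2 gives 240 nM, a lower number that lies beyond the scatter.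

Compound 3 `CC1(CC[C@H](c2ccc(C(=O)NCc3nn[nH]n3)cc2)N2C(=O)C(c3cc(Cl)cc(Cl)c3)=N[C@]23CC[C@@H](C(C)(C)C)CC3)CC1` keeps the dichlorophenyl group of compound 1 and changes only the chain: 2-(1-methylcyclopropyl)ethyl in place of isopropyl on a saturated chain carbon bound to an amide-type nitrogen in a ring and an aromatic carbon. The new group brings the chain length closer to that of compound 2. Since the change in compound 2 mixes two alterations, the expected step from compound 1 to compound 3 rests on that comparison alone and is estimated as a 3.7-fold lower number from compound 1 to compound 3 (0.56 log units; beyond the scatter). For compound 3 in this assay the expected value is 600 nM, within a range from 200 nM to 1800 nM.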

Compound 3, half-maximal inhibitory concentration: 100 nM
For compound 3 the middle estimate is 6.0-fold (0.78 log units) above the measured one; the whole stated range lies above it.
By their numbers in this assay, from the lowest: compound 3; then compound 2; then compound 1.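

With the dichlorophenyl group and the rest of the core held fixed, replacing isopropyl with 2-(1-methylcyclopropyl)ethyl on the saturated chain carbon gives in this assay a 22-fold lower number from compound 1 to compound 3 (1.34 log units; beyond the scatter). Compound 1 and compound 2 differ in two places, so their gap could not be tied to the chain, whereas this step belongs to the chain change alone. The entering group adds carbon atoms and a three-membered ring, and neither group has hydrogen-bond donors or acceptors, but no measurement here explains the lower number.

Chain length and the ring change together in this step, so the compounds shown cannot tell which of the two matters. A straight hexyl chain on this carbon would help to separate them, and a terminal amine on the chain would test a charged group there.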